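Swapping a hydroxyethyl for a nitrile on a pyridone amide

The source may hold more compounds than are shown below. What is called first, only, known or untested is meant among the compounds shown, and "the series" means these compounds.

Compound 1 `CNC(=O)c1cccn(Cc2ccccc2)c1=O` gives 3 in a physicochemical assay for lipophilicity, at pH 7.4; on this read-out lower numbers stand for lower lipophilicity and higher numbers for higher lipophilicity. Among the measured compounds shown here, compound 2 `CNC(=O)c1cc(C(=O)NC)c(=O)n(Cc2ccccc2)c1` gives 2.4, and the only single-point step here is a number 0.60 log units lower from compound 1 to compound 2 (beyond the scatter). Compound 3 `CNC(=O)c1cc(C(=O)NC2CC2)cn(Cc2cccc([C@@H](C)O)c2)c1=O` gives 2.2, the lowest of the three numbers; its gap to compound 2 lies within the scatter, while its gap to compound 1 lies beyond it. Compound 4 `CNC(=O)c1cc(C(=O)NC2CC2)cn(Cc2cccc(C#N)c2)c1=O` is still unmeasured, and it differs from compound 3 by cyano in place of 1-hydroxyethyl on an aromatic carbon. For the measured compounds named here, no measured step covers this kind of exchange; the one known step concerns a different group on a different position and so gives no direct guide. The expected step is a number 0.20 log units higher from compound 3 to compound 4 (within the scatter), small and within the scatter. Compound 4 is therefore estimated at 2.4, between 1.9 and 2.9.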

Compound 4, distribution coefficient: 2.6
Beside the measured number, compound 4's estimate is 0.20 log units below it, and the stated range covers the measured number.
By their numbers in this assay, from the lowest: compounds 3, 2 and 4 (each within the scatter of the next, the first and the last beyond it); then compound 1.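

Among the compounds shown here, the change from 3-(1-hydroxyethyl)phenyl to 3-cyanophenyl is the only measured exchange at this place, and in this assay it reads as a number 0.40 log units higher from compound 3 to compound 4 (beyond the scatter). So a swap on this aromatic carbon, meta to a large group, can move the number beyond the scatter, with a hydrogen-bond donor leaving and none entering. No measurement shown here accounts for the size of this step. As far as these compounds go, how an amine, a carboxylic acid or a methoxy group would read at this place stays open. So does whether the same exchange gives a similar step in compounds with another amide.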